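Swapping the aromatic ring at the exocyclic double bond

The compounds below may be only part of what the source reports. "The series", "measured", "known", "first", "only" and "open" are said of these compounds alone.

Of the compounds shown here, three have so far been tested in a functional assay on DU-145 cells (Homo sapiens) for inhibition, read by trypan blue exclusion, with a stated time of 96 h; a lower number here means a stronger inhibitor of growth, a higher number a weaker inhibitor of growth. Compound 1 `O=C(/C(=C\c1cc([N+](=O)[O-])ccc1F)S(=O)(=O)Cc1ccc(F)cc1)c1ccc(Br)cc1` gives only a limit of the assay, > 100000 nM. Compound 2 `Cc1ccc(/C=C(/SCc2ccc(F)cc2)C(=O)c2ccc(Cl)cc2)s1` likewise gives only a limit, > 100000 nM. Compound 3 `Cc1ccc(S/C(=C/c2sccc2C)C(=O)c2ccc(Cl)cc2)cc1` gives a number, 50000 nM. Compound 1 thus stands at the limit of > 100000 nM in this assay, at which 2 of the 3 values shown sit, with no measured number of its own. Compound 4 `O=C(/C(=C\c1ccc(Br)cc1)S(=O)(=O)Cc1ccc(F)cc1)c1ccc(Br)cc1` differs from compound 1 in one place: 4-bromophenyl in place of 2-fluoro-5-nitrophenyl on a double-bonded chain carbon bound to a double-bonded chain carbon. Within the data shown here, no two measured compounds differ in a single place, so no measured step guides this change. The expected step is an at least 1.2-fold lower number from compound 1 to compound 4 (0.09 log units; that floor lies within the scatter), small and in no sure direction, with a fair chance that only a limit is reported again. Compound 4 is expected to give about 80000 nM, between 20000 nM and 300000 nM.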

Compound 4, concentration for 50% growth inhibition: 25000 nM
Beside the measured number, compound 4's estimate is 3.2-fold (0.51 log units) above it; low and high end bracket the measured number.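

In this assay, the aromatic ring on this double-bonded chain carbon matters: 4-bromophenyl in place of 2-fluoro-5-nitrophenyl gives an at least 4.0-fold lower number from compound 1 to compound 4 (0.60 log units; beyond the scatter). Among these compounds, this is the first comparison here of compounds differing in one place, and the step lies beyond the scatter. Its full size stays unknown, since compound 1 gives only a limit of the assay: the limit of > 100000 nM in this assay, at which 2 of the 4 values shown sit.

The compounds shown do not separate the loss of the nitro group or the fluorine from the gain of the bromine. From the compounds shown here alone, how an amine or a carboxylic acid on this ring would read also remains open.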